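The source may hold more compounds than are shown below. What is called first, only, known or untested is meant among the compounds shown, and "the series" means these compounds.

Going by the values given here, compound 2 `CC(C)c1onc(-c2c(Cl)cccc2Cl)c1COc1ccc2c(ccn2Cc2cccc(C(=O)O)c2)c1` gives the higher of the two numbers measured so far: in an assay on CV-1 cells with Bile acid receptor (Homo sapiens) as the target, read by a luciferase reporter (a higher number here means that more compound is needed for the effect, a lower number that less compound is needed), compound 2 gives 210 nM, whereas compound 1 `CC(C)c1onc(-c2c(Cl)cccc2Cl)c1COc1ccc2cc(-c3cccc(C(=O)O)c3)sc2c1` gives 63 nM. Compound 3 `CC(C)c1onc(-c2c(Cl)cccc2Cl)c1COc1ccc2c(ccn2Cc2ccc(C(=O)O)cc2)c1` keeps the core of compound 2 and differs from it only in one respect: 4-carboxyphenyl in place of 3-carboxyphenyl on a saturated chain carbon bound to an aromatic nitrogen. Among the compounds with values here, no measured pair shows what this change does on its own, so the expected step of a 1.2-fold lower number from compound 2 to compound 3 (0.07 log units; within the scatter) in this assay is small and has no clear direction beyond the scatter. Compound 3 is therefore estimated to give about 180 nM, most likely falling between 50 nM and 650 nM.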

Compound 3, half-maximal effective concentration: 330 nM
For compound 3 the middle estimate is 1.8-fold (0.26 log units) below the measured one; the range from low to high includes it.
By their numbers in this assay, from the lowest: compound 1; then compounds 2 and 3 (each within the scatter of the next).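

Swapping 3-carboxyphenyl for 4-carboxyphenyl on this saturated chain carbon gives the first single-change comparison at this position in this assay (a 1.6-fold higher number from compound 2 to compound 3 (0.20 log units; within the scatter)). The two placements of the carboxylic acid on the ring are therefore not told apart by this assay. Nothing measured here offers an explanation for this result.

The compounds shown leave open whether the carboxylic acid is needed at this position at all. A primary amide in its place, or a longer chain carrying the acid, could read quite differently.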